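Trading Methoxy for Chloropropyl on the Amide Chain

A few compounds are considered here, and "the series" means these few. Any claim that something is new, unique, unknown or untested is made for them only; others in the source may bear on it.

Of the compounds shown here, three that share one core have been tested in a functional assay on MGC-803 cells (Homo sapiens) for inhibition, read by MTT assay, with a stated time of 48 h; on this read-out higher numbers stand for weaker inhibition and lower numbers for stronger inhibition. Compound 2 `COCC(=O)N(Cc1ccc(OC)c(O)c1)c1cc(OC)c(OC)c(OC)c1` gives 79 nM, the lowest number of the three. Compound 1 `C/C=C/C(=O)N(Cc1ccc(OC)c([N+](=O)[O-])c1)c1cc(OC)c(OC)c(OC)c1` gives 590 nM in this assay, and compound 3 `COc1ccc(CNc2cc(OC)c(OC)c(OC)c2)cc1C`, which carries no carbonyl on its nitrogen, gives 56800 nM. Both gaps to compound 2 lie beyond the scatter, so compound 2 stands as the most potent of the measured set.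

Compound 4 `COc1ccc(CN(C(=O)CCCCCl)c2cc(OC)c(OC)c(OC)c2)cc1O` has not been measured. It differs from compound 2 in one place: 3-chloropropyl in place of methoxy on a saturated chain carbon bound to a carbonyl carbon. Among the compounds with values here, no measured pair isolates this change, since compound 1 and compound 3 each differ from compound 2 in more than one place. The carbonyl on the nitrogen is kept in compound 4, so it is expected to remain far from the weak number of compound 3. The step from compound 2 is expected to be small, a mild weakening of a 2.5-fold higher number from compound 2 to compound 4 (0.40 log units; beyond the scatter), which may fall within the scatter. Compound 4 is therefore estimated at 200 nM, with a range from 40 nM to 1000 nM.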

Compound 4, half-maximal inhibitory concentration: 540 nM
The estimate for compound 4 lay 2.7-fold (0.43 log units) below the measured number; the range from low to high includes it.
By their numbers in this assay, from the lowest: compound 2; then compounds 4 and 1 (each within the scatter of the next); then compound 3.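

In this assay, the change of methoxy to 3-chloropropyl on a saturated chain carbon bound to a carbonyl carbon gives a 6.8-fold higher number from compound 2 to compound 4 (0.83 log units; beyond the scatter). Within the data shown here, this is the first pair that isolates this position, and it shows that the number responds to what the amide chain carries, with the exchange costing potency while the rest of the molecule stays the same. The change removes a hydrogen-bond acceptor and adds heavy atoms and a chlorine together, and nothing available explains the step.

The compounds shown leave open whether the loss follows the oxygen that leaves, the chlorine that enters or the length of the chain. A plain propyl group, or a propyl chain ending in an amine or a carboxylic acid, would bear on that question at this place.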